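From 3-methylphenyl to 4-methylphenyl: working notes on the series

The compounds below may be only part of what the source reports. "The series", "measured", "known", "first", "only" and "open" are said of these compounds alone.

Measured in an ADME assay on MDBK cells (Bos taurus) for cytotoxicity; on this read-out lower numbers stand for higher toxicity in this test and higher numbers for lower toxicity in this test:
- compound 1 `Fc1cccc(F)c1Cn1ccc2nc(-c3ccccc3)nc-2c1`: > 100000 nM
- compound 2 `c1ccc(Cn2ccc3nc(-c4ccccc4)nc-3c2)cc1`: > 100000 nM
- compound 3 `Cc1cccc(Cn2ccc3nc(-c4ccccc4)nc-3c2)c1`: > 100000 nM

Each of these values is a limit of the assay and not a number. Compound 3 gives > 100000 nM in this assay, which is a limit. The measured set therefore shares a single position, (the limit of > 100000 nM in this assay, at which 3 of the 3 values shown sit), and compound 3 cannot be ranked against the others.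

The next compound is compound 4 `Cc1ccc(Cn2ccc3nc(-c4ccccc4)nc-3c2)cc1`, with 4-methylphenyl in place of 3-methylphenyl on a saturated chain carbon bound to an aromatic nitrogen. Within the data shown here, three measured steps bear on this change. Methyl in place of hydrogen on an aromatic carbon gives a step that the two limits leave unreadable from compound 2 to compound 3. The two changes of the group on the chain carbon give a step that the two limits leave unreadable from compound 1 to compound 2 and a step that the two limits leave unreadable from compound 1 to compound 3. None of them has a readable size, so they offer no direction for the change.

No step beyond the scatter is expected, and the estimated step is a step that the limit leaves unreadable from compound 3 to compound 4. This expectation rests on compound 3, whose value of > 100000 nM is a limit. A report as a limit is also the likely outcome for the next measurement. The estimate for compound 4 is 120000 nM, with an expected range of 60000 nM to 250000 nM.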

Compound 4, half-maximal cytotoxic concentration: > 100000 nM
Compound 4: a limit, no number; the forecaster's own chance of this, stated with the estimate: 90%; the middle value lies beyond the limit too.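

Compound 4 gives > 100000 nM in this assay, which is a limit. No step between compound 4 and compound 1, compound 2 or compound 3 can be read, and the series keeps a single position: the limit of > 100000 nM in this assay, at which 4 of the 4 values shown sit.

The compounds shown leave open whether any of the four differ from one another in this assay.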